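The source may report more compounds than this note shows. Statements on the series, on what has been measured and on what is new or still open speak of the compounds shown alone.

In a functional assay for agonist activity at G protein-coupled receptor 88 (Homo sapiens), read by HTRF and cAMP accumulation (a higher number here means that more compound is needed for the effect, a lower number that less compound is needed), compound 1 `CC[C@H](C)[C@H](N)CN(C(=O)[C@@H]1C[C@H]1c1ccccc1)c1ccc(-c2ccccc2)cc1` gives 230 nM; 800 nM (2 entries), as recorded in the several entries of compound 1 in this assay, 230 nM; 800 nM (2 entries). Compound 2 `CC[C@H](C)[C@H](N)CN(C(=O)[C@@H]1C[C@H]1c1cccc(Cl)c1)c1ccc(-c2ccccc2)cc1`, carrying a 3-chlorophenyl on the three-membered ring, gives 2200 nM. For compound 3 `CC[C@H](C)[C@H](N)CN(C(=O)[C@@H]1C[C@H]1c1ccc(OC)cc1)c1ccc(-c2ccccc2)cc1` only a limit is available: in this assay compound 3 gives > 25000 nM, which is a limit of the measurement and not a number. Compound 3 therefore stands at the weak end of the three, at the limit of > 25000 nM in this assay, at which 1 of the 3 values shown sits, and the step of an at least 11-fold higher number from compound 2 to compound 3 (1.05 log units; beyond the scatter) is known only as a lower bound on its size. Compound 4 `CC[C@H](C)[C@H](N)CN(C(=O)[C@@H]1C[C@H]1c1cccc(OC)c1)c1ccc(-c2ccccc2)cc1` has not yet been measured; it differs from compound 3 by 3-methoxyphenyl in place of 4-methoxyphenyl on a saturated ring carbon. For the measured compounds named here, the only measured step touching this part of the molecule is an at least 11-fold higher number from compound 2 to compound 3 (1.05 log units; beyond the scatter), which compares a chloro with a methoxy rather than two positions of the same methoxy, so no measured step directly covers the change at hand. Compound 4 is expected to sit between the limit of compound 3 and the value of compound 2, at an estimated 6000 nM, within 1500 nM to 25000 nM. This estimate corresponds to an expected step of an at least 4.1-fold lower number from compound 3 to compound 4 (0.61 log units; beyond the scatter).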

Compound 4, half-maximal effective concentration: 3000 nM
The estimate for compound 4 lay 2.0-fold (0.30 log units) above the measured number; the range from low to high includes it.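

Moving the methoxy so that 4-methoxyphenyl becomes 3-methoxyphenyl, with the same atoms joined differently, gives in this assay an at least 8.3-fold lower number from compound 3 to compound 4 (0.92 log units; beyond the scatter), so where the methoxy sits matters here and not only that it is present. Compound 3 carries a limit and not a number, so that step is known only as a lower bound on its size: the limit of > 25000 nM in this assay, at which 1 of the 4 values shown sits. The swap between 3-chlorophenyl and 3-methoxyphenyl gives a 1.4-fold higher number from compound 2 to compound 4 (0.13 log units; within the scatter), so chloro and methoxy cannot be told apart in this pair, and the earlier loss at compound 3 goes with the 4-methoxyphenyl group rather than with methoxy as such.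

On these data alone, it stays open whether a chloro set where the methoxy of compound 3 sits would lose as much, since that place is seen with methoxy alone. As far as these compounds go, it is also open how an ethoxy, an amine or a carboxylic acid would fare in place of the methoxy of compound 4.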